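This account rests on a few compounds, and the source may have more. Where it says the series, first, only, none or still open, it means among the compounds named here.

Three compounds here share one core and differ only in the group on one sulfonyl sulfur. Compound 1 `O=C([C@@H]1CCCN(S(=O)(=O)c2ccc(S(=O)(=O)N3CC[C@@H](O)C3)cc2)C1)N1CCC(F)(F)CC1` carries 3-hydroxypyrrolidin-1-yl there, compound 2 `O=C([C@@H]1CCCN(S(=O)(=O)c2ccc(S(=O)(=O)C3CCC3)cc2)C1)N1CCC(F)(F)CC1` carries cyclobutyl, and compound 3 `CC(C)S(=O)(=O)c1ccc(S(=O)(=O)N2CCC[C@@H](C(=O)N3CCC(F)(F)CC3)C2)cc1` carries isopropyl. In an ADME assay on microsomes from liver (Mus musculus) for metabolic stability, read by LC-MS, using NADPH, with a stated time of 60 min, tested at 10 uM (on this read-out higher numbers stand for a longer-lived compound and lower numbers for a shorter-lived compound), compound 1 gives 0.437 h and compound 2 gives 0.733 h. For compound 3 the read-out stops at a limit of the assay, > 1 h, so only a floor is known for it, as shown by the limit of > 1 h in this assay, at which 1 of the 3 values shown sits. The measured steps are a 1.7-fold higher number from compound 1 to compound 2 (0.22 log units; within the scatter), an at least 2.2-fold higher number from compound 1 to compound 3 (0.35 log units; beyond the scatter) and an at least 1.3-fold higher number from compound 2 to compound 3 (0.13 log units; that floor lies within the scatter); compound 3 thus sits at or beyond the top of the three. Compound 4 `CN(C)S(=O)(=O)c1ccc(S(=O)(=O)N2CCC[C@@H](C(=O)N3CCC(F)(F)CC3)C2)cc1` is compound 3 with dimethylamino in place of isopropyl on a sulfonyl sulfur. For the measured compounds named here, no measured step exchanges a carbon group for a nitrogen group on that sulfur, so the two steps ending at compound 3 are the nearest guides, and they span from within the scatter to modest. Compound 4 is estimated at 0.9 h, with a range from 0.4 h to 1.6 h. The expected step is an at least 1.1-fold lower number from compound 3 to compound 4 (0.04 log units; that floor lies within the scatter), small enough to stay within the scatter.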

Compound 4, half-life: 0.533 h
Estimate against measurement, compound 4: 1.7-fold (0.23 log units) above; measured number inside the range.
By their numbers in this assay, from the lowest: compounds 1, 4 and 2 (each within the scatter of the next). At a limit, above all of these: compound 3.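

Dimethylamino brings a nitrogen group onto this sulfonyl sulfur in place of a carbon group, and the exchange for isopropyl gives an at least 1.8-fold lower number from compound 3 to compound 4 (0.27 log units; that floor lies within the scatter) in this assay, which is only a floor because compound 3 stands at a limit of the assay: the limit of > 1 h in this assay, at which 1 of the 4 values shown sits. The other two exchanges give a 1.4-fold lower number from compound 2 to compound 4 (0.14 log units; within the scatter) and a 1.2-fold higher number from compound 1 to compound 4 (0.09 log units; within the scatter) and so separate none of these groups from dimethylamino. Carbon groups and nitrogen groups on this sulfur therefore do not fall into two clear sets, since compound 2, with cyclobutyl, stays within the scatter of both compound 1 and compound 4.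

Going by these compounds, how far compound 3 truly lies above compound 4 remains open. So does where a tert-butyl group or a morpholine ring on this sulfur would fall.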